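From 4-Bromophenyl to 2-Bromophenyl: Expected Cytotoxicity

The source may report more compounds than this note shows. Statements on the series, on what has been measured and on what is new or still open speak of the compounds shown alone.

Compound 1 `COC(=O)c1cc(-c2cccc(NC(=O)c3ccc(/C=C/C(=O)c4cccnc4)cc3)c2)on1` — "not determined" (no result reported)
Compound 2 `COC(=O)c1cc(-c2cccc(NC(=O)c3ccc(/C=C/C(=O)c4ccc(Br)cc4)cc3)c2)on1` — > 20 ug/mL
Compound 3 `CCOC(=O)c1cc(-c2cccc(NC(=O)c3cccc(C(F)(F)F)c3)c2)on1` — "not determined" (no result reported)

In an ADME assay on Vero cells (Chlorocebus sabaeus) for cytotoxicity, read by MTT assay, with a stated time of 72 h (on this read-out higher numbers stand for lower toxicity in this test and lower numbers for higher toxicity in this test), compound 2 reaches only a limit of the assay, > 20 ug/mL. Going by the values given here, compound 1 and compound 3 carry no result in this assay, so compound 2 is the sole entry with any reading, and it sits at the limit of > 20 ug/mL in this assay, at which 1 of the 3 values shown sits. Among the compounds with values here, no measured step between compounds exists here.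

Compound 4 `COC(=O)c1cc(-c2cccc(NC(=O)c3ccc(/C=C/C(=O)c4ccccc4Br)cc3)c2)on1` differs from compound 2 by 2-bromophenyl in place of 4-bromophenyl on a carbonyl carbon. With nothing measured to weigh against, no change beyond the scatter in this assay is expected from compound 2 to compound 4, and a limit is again the likely report. The step that the limit leaves unreadable from compound 2 to compound 4 is expected to be essentially none. Compound 4 is therefore estimated at 25 ug/mL, between 10 ug/mL and 60 ug/mL.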

Compound 4, half-maximal cytotoxic concentration: > 40 ug/mL
Compound 4 gave a limit, no number; the forecaster's own chance of this, stated with the estimate: 80%; middle value at least 1.6-fold (0.20 log units) from the limit.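

Going by these compounds alone, compound 2 and compound 4 each reach only a limit in this assay, and no step between them can be read. The compounds shown leave open whether 2-bromophenyl in place of 4-bromophenyl changes the half-maximal cytotoxic concentration at all.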